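Swapping 4-iodophenyl for 3,4-dichlorophenyl in the series

The source may report more compounds than this note shows. Statements on the series, on what has been measured and on what is new or still open speak of the compounds shown alone.

In a functional assay on MOLT-4 cells (Homo sapiens) for antiproliferative activity (on this read-out higher numbers stand for weaker inhibition and lower numbers for stronger inhibition), compound 1 `COc1cc(C(=O)c2sc(-c3ccc(-c4ccccc4)cc3)cc2N)cc(OC)c1OC` reads > 10000 nM, which is a limit of the assay. Compound 2 `COc1cc(C(=O)c2sc(-c3ccc(I)cc3)cc2N)cc(OC)c1OC` gives 190 nM, and compound 3 `COc1cc(C(=O)c2sc(-c3ccccc3Cl)cc2N)cc(OC)c1OC` gives 17 nM. Among the measured compounds shown here, compound 2 therefore holds the higher of the two actual numbers, with compound 3 the only numeric neighbour.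

Compound 4 `COc1cc(C(=O)c2sc(-c3ccc(Cl)c(Cl)c3)cc2N)cc(OC)c1OC` has not yet been measured. It differs from compound 2 by 3,4-dichlorophenyl in place of 4-iodophenyl on an aromatic carbon, next to the ring sulfur: 3,4-dichlorophenyl in place of 4-iodophenyl on an aromatic carbon.

For the measured compounds named here, two measured steps bear on this change. The closer one is an 11-fold lower number from compound 2 to compound 3 (1.05 log units; beyond the scatter), where 2-chlorophenyl replaces the same 4-iodophenyl and shares chlorine with the entering group. The other is an at least 52-fold lower number from compound 1 to compound 2 (1.72 log units; beyond the scatter), with iodo in place of phenyl, which is also large and runs in the same direction. Going by the values given here, neither step tests a 3,4-dichlorophenyl group, so only a cautious transfer is justified: a lower number in this assay is expected, but a smaller move than the one to compound 3, possibly not clearing the scatter.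

The estimated change is a 2.1-fold lower number from compound 2 to compound 4 (0.32 log units; beyond the scatter).

For compound 4, the expected value is 90 nM, with an estimated range of 20 nM to 400 nM.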

Compound 4, half-maximal inhibitory concentration: 270 nM
Estimate against measurement, compound 4: 3.0-fold (0.48 log units) below; low and high end bracket the measured number.
By their numbers in this assay, from the lowest: compound 3; then compounds 2 and 4 (each within the scatter of the next). At a limit, above all of these: compound 1.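

In this assay, a 1.4-fold higher number from compound 2 to compound 4 (0.15 log units; within the scatter), so 3,4-dichlorophenyl and 4-iodophenyl, on the aromatic carbon next to the ring sulfur, cannot be told apart on this read-out. Chlorine on the phenyl ring does not by itself bring the low number of compound 3, since a 16-fold higher number from compound 3 to compound 4 (1.20 log units; beyond the scatter); among the compounds shown, 2-chlorophenyl is the only group that stands apart from the others at this position, and the chlorine shared by compound 3 and compound 4 does not carry over from one to the other. No measured property in hand accounts for either step.

Still open, as far as these compounds go, is whether the low number of compound 3 survives with fluorine or a methoxy group in place of its chlorine, and whether an amine or a carboxylic acid on this phenyl ring is tolerated at all. Compound 1 reads > 10000 nM, which is a limit of the assay, so how much larger the group at this position can become than in compound 2 also remains undecided.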